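Iodo in place of fluoro: expected inhibition of compound 4

This account rests on a few compounds, and the source may have more. Where it says the series, first, only, none or still open, it means among the compounds named here.

Of the compounds shown here, three have been measured in a functional assay on the whole organism (strain albino) with Mus musculus as the target, at a dose of 100 mg/kg by the intraperitoneal route; a higher number here means more inhibition at the dose given (going by the name of the read-out), a lower number less inhibition. Compound 1 `O=C(Nc1ccc(I)cc1)Nn1c(-c2ccccc2)nc2ccccc2c1=O` gives 60%. Compound 2 `CCc1nc2ccccc2c(=O)n1NC(=O)Nc1ccc([N+](=O)[O-])cc1` gives 41%, and compound 3 `CCc1nc2ccccc2c(=O)n1NC(=O)Nc1ccc(F)cc1` gives 51%. Compound 3 stands second highest of the three numbers; its nearest neighbour is compound 1 and its furthest is compound 2, and both gaps lie within the scatter.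

Among the compounds with values here, the only single-point step measured so far, a number 10 percentage points higher from compound 2 to compound 3 (within the scatter), is within the scatter. It concerns the same aromatic carbon as the change now at hand, but with a different pair of groups, so it bears on the present step only loosely.

Compound 4 `CCc1nc2ccccc2c(=O)n1NC(=O)Nc1ccc(I)cc1` has not yet been measured in this assay. It differs from compound 3 as follows: iodo in place of fluoro on an aromatic carbon. Within the data shown here, compound 1 also carries iodo on that carbon but differs from compound 3 elsewhere as well; no single-point step connects them, so their values can only be set side by side: compound 1 at 60% and compound 3 at 51% sit within the scatter of each other.

On this basis the expected step of a number 4 percentage points higher from compound 3 to compound 4 (within the scatter) is small, with no direction beyond the scatter. Compound 4 is therefore estimated at 55%, in the range 35% to 75%.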

Compound 4, a percentage reported as inhibition, in the whole organism at one dose (the size of the read-out at that dose, not a potency): 55%
Compound 4: the middle estimate sits on the measured number at the digits printed, within the range that was stated.
By their numbers in this assay, from the lowest: compounds 2, 3, 4 and 1 (each within the scatter of the next, the first and the last beyond it).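

In this assay the exchange at this aromatic carbon gives a number 4 percentage points higher from compound 3 to compound 4 (within the scatter) and so does not separate iodo from fluoro, even though these two groups sit at the far ends of the halogens in the series. Against nitro, the reading a number 14 percentage points higher from compound 2 to compound 4 (beyond the scatter) is the first step here to pass the scatter, though only modestly, while a number 10 percentage points higher from compound 2 to compound 3 (within the scatter) does not pass it, so only iodo is set apart from nitro by the numbers. Within the data shown here, compound 4 also gives the first single-point reading at the other varied site, where a number 5 percentage points lower from compound 1 to compound 4 (within the scatter) does not separate ethyl from phenyl with iodo in place on the aromatic ring; nothing measured beyond these percentages accounts for any of these steps.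

Open, as far as these compounds go, is whether an amine, a carboxylic acid or a methoxy group on this aromatic carbon would stand apart from fluoro and iodo, and where chloro and bromo would fall. Also open, from the compounds shown here alone, is whether a longer chain such as butyl in place of ethyl would change the number, and whether ethyl and phenyl stay inseparable with fluoro or nitro on the aromatic ring.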